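From Phenyl to Phenoxy on a Saturated Ring Carbon

The compounds below may be only part of what the source reports. "The series", "measured", "known", "first", "only" and "open" are said of these compounds alone.

Compound 1 `CC1CCC(C)N1CCCNC(=O)C(c1ccccc1)c1ccccc1`: 4600 nM
Compound 2 `CC1CN(CCCNC(=O)C(c2ccccc2)c2ccccc2)CC(C)O1`: 2700 nM
Compound 3 `O=C(NCCCN1CCC(c2ccccc2)CC1)C(c1ccccc1)c1ccccc1`: 1100 nM

Three compounds share the same amide and chain and differ only in the ring attached at the far end of that chain. In an assay on CHO cells for inhibition of sodium channel protein type 2 subunit alpha (Rattus norvegicus) (on this read-out higher numbers stand for weaker inhibition and lower numbers for stronger inhibition), compound 3 gives 1100 nM, the lowest number of the three, and its distance from both compound 2 and compound 1 lies beyond the usual scatter; the other two numbers, compound 2 at 2700 nM and compound 1 at 4600 nM, sit higher.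

Compound 4 `O=C(NCCCN1CCC(Oc2ccccc2)CC1)C(c1ccccc1)c1ccccc1` keeps the core of compound 3 and changes only one spot: phenoxy in place of phenyl on a saturated ring carbon. For the measured compounds named here, no measured pair covers a phenyl-to-phenoxy swap. Going by the values given here, the only measured step, a 1.7-fold lower number from compound 1 to compound 2 (0.23 log units; within the scatter), exchanged one saturated ring for another and stayed within the scatter, so it offers weak guidance at best. With no direct evidence, the sensible expectation is a number near that of compound 3, with room on either side.

Compound 4 is therefore expected to give about 1300 nM in this assay, estimated between 500 nM and 3500 nM. This corresponds to an expected step of a 1.2-fold higher number from compound 3 to compound 4 (0.07 log units; within the scatter), which stays within the scatter.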

Compound 4, half-maximal inhibitory concentration: 1400 nM
For compound 4 the middle estimate is 1.1-fold (0.03 log units) below the measured one; the range from low to high includes it.
By their numbers in this assay, from the lowest: compounds 3, 4, 2 and 1 (each within the scatter of the next, the first and the last beyond it).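

Swapping phenyl for phenoxy on a saturated ring carbon, three ring bonds from the ring nitrogen, gives a 1.3-fold higher number from compound 3 to compound 4 (0.10 log units; within the scatter), so this assay does not separate these two compounds. The earlier compounds shown here varied only the ring at the end of the chain, whereas this pair keeps that ring and changes the group it carries, adding one oxygen atom and one hydrogen-bond acceptor while the aromatic ring stays in the molecule; at this position, that change leaves the number within the scatter. Nothing available here explains this outcome.

The compounds shown leave open whether the number would also hold with a methylene group or an amine nitrogen in place of the phenoxy oxygen, or with a chlorine atom or a methoxy group on the aromatic ring. They also leave open whether phenoxy would give a similar result on a longer chain, since the chain here is the same in compound 3 and compound 4.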